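Cyanophenyl Amide in Place of Fluorophenyl Amide

The source may report more compounds than this note shows. Statements on the series, on what has been measured and on what is new or still open speak of the compounds shown alone.

Compound 1 `O=C(Nc1cccc(-c2oc3cc(-c4ccc(F)cc4)ccc3c(=O)c2O)c1)c1ccc(F)cc1F` and compound 2 `O=C(Nc1cccc(-c2oc3cc(-c4ccc(F)cc4)ccc3c(=O)c2O)c1)c1cccc(F)c1` share a common core and differ only in the aryl group on the carbonyl carbon. In a functional assay on A549 cells (Homo sapiens) for antiproliferative activity, read by CCK-8 assay, with a stated time of 72 h (a higher number here means a weaker inhibitor, a lower number a stronger inhibitor), compound 1 gives 20500 nM, while compound 2 gives 15400 nM. The step of a 1.3-fold lower number from compound 1 to compound 2 (0.12 log units; within the scatter) lies within the scatter, so the two compounds cannot be ordered; compound 2 simply holds the lower of the two numbers seen so far.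

Compound 3 `N#Cc1ccc(C(=O)Nc2cccc(-c3oc4cc(-c5ccc(F)cc5)ccc4c(=O)c3O)c2)cc1` has not yet been measured. It differs from compound 2 as follows: 4-cyanophenyl in place of 3-fluorophenyl on a carbonyl carbon. Among the measured compounds shown here, the only measured step that bears on this change is a 1.3-fold lower number from compound 1 to compound 2 (0.12 log units; within the scatter), which is also a swap of the aryl group on the carbonyl carbon, and it stayed within the scatter. With no further guidance, compound 3 is expected to give 15000 nM in this assay, with a range from 6000 nM to 40000 nM. The expected step of a 1.0-fold lower number from compound 2 to compound 3 (0.01 log units; within the scatter) is therefore estimated to stay within the scatter, with no preferred direction.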

Compound 3, half-maximal inhibitory concentration: 2360 nM
Compound 3: the middle estimate sits 6.4-fold (0.80 log units) above what was measured, outside the stated range (below it).
By their numbers in this assay, from the lowest: compound 3; then compounds 2 and 1 (each within the scatter of the next).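

The aryl group on the carbonyl carbon proves able to move the result in this assay: 4-cyanophenyl in place of 3-fluorophenyl gives a 6.5-fold lower number from compound 2 to compound 3 (0.81 log units; beyond the scatter) and 4-cyanophenyl in place of 2,4-difluorophenyl gives an 8.7-fold lower number from compound 1 to compound 3 (0.94 log units; beyond the scatter) on the same shared core. Both steps lie beyond the scatter, whereas the swap between the two fluorinated aryl groups did not, so the fluorinated pair alone gave no sign that this position could respond and compound 3 now has the lowest number of the three, though the size of the step is modest. Nothing measured here accounts for the difference between the 4-cyanophenyl amide and its fluorinated counterparts.

The change from 3-fluorophenyl to 4-cyanophenyl replaces the substituent and alters its place on the ring at once, so the compounds shown cannot separate the contribution of the nitrile from that of its location. On these data alone, it also remains open whether the trend would extend to a phenyl ring carrying a carboxylic acid, an amine or a trifluoromethyl group in place of the nitrile, or to an unsubstituted phenyl ring.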